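The source may hold more compounds than are shown below. What is called first, only, known or untested is meant among the compounds shown, and "the series" means these compounds.

Measured so far in a functional assay on the whole organism (strain Sprague-Dawley CD) for inhibition, with Rattus norvegicus as the target, read by paw edema, at a dose of 30 mg/kg by the intraperitoneal route; on this read-out lower numbers stand for a weaker effect and higher numbers for a stronger effect at the one dose given:
Compound 1, `CCOC(=O)C(=O)Nc1ccccc(C)c1=O`, gives 60%.
Compound 2, `CCOC(=O)C(=O)Nc1ccccc(Br)c1=O`, gives 52%.
Compound 3, `CCOC(=O)C(=O)Nc1ccccc(NC)c1=O`, gives 83%.

Compound 3 stands highest of the three numbers. Its nearest neighbour is compound 1, and the step of a number 23 percentage points higher from compound 1 to compound 3 (beyond the scatter) lies beyond the scatter; the step of a number 31 percentage points higher from compound 2 to compound 3 (beyond the scatter) is larger still. Between compound 1 and compound 2 the step of a number 8 percentage points lower from compound 1 to compound 2 (within the scatter) stays within the scatter, so those two cannot be ordered.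

Compound 4, `CCOC(=O)C(=O)Nc1ccccc(-c2ccccc2)c1=O`, has not yet been measured in this assay. The change from compound 3 is: phenyl in place of methylamino on an aromatic carbon

The two steps that bear on this change are the ones that brought methylamino in: a number 23 percentage points higher from compound 1 to compound 3 (beyond the scatter) and a number 31 percentage points higher from compound 2 to compound 3 (beyond the scatter). Both were gains beyond the scatter, and in compound 4 methylamino leaves again. Within the data shown here, no measured compound carries phenyl at this position, so the size of the phenyl effect itself is unknown; the expectation rests only on the loss of methylamino. As far as these compounds go, a drop beyond the scatter is therefore expected, roughly of the size seen in reverse, with a wide range because phenyl is untested: the expected step is a number 25 percentage points lower from compound 3 to compound 4 (beyond the scatter). For compound 4 the estimate in this assay is 58%, within a range from 40% to 75%.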

Compound 4, a percentage reported as inhibition, in the whole organism at one dose (the size of the read-out at that dose, not a potency): 72%
Compound 4: middle estimate off by 14 percentage points, on the low side; the range from low to high includes it.
By their numbers in this assay, from the lowest: compounds 2 and 1 (each within the scatter of the next); then compound 4; then compound 3.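

In this assay the position on the seven-membered aromatic ring takes phenyl, a group of six heavy atoms with a ring of its own, and the number still rises over bromo, a number 20 percentage points higher from compound 2 to compound 4 (beyond the scatter), and over methyl, a number 12 percentage points higher from compound 1 to compound 4 (beyond the scatter). Until now only methylamino had stood above those two groups, so a gain over them at this position does not require a hydrogen-bond donor or acceptor on the group, as phenyl has neither. Methylamino nevertheless stays ahead of phenyl, a number 11 percentage points lower from compound 3 to compound 4 (beyond the scatter), so exchanging it gives up only part of its lead over methyl and bromo. Nothing available explains why the groups fall in this order.

The compounds shown leave open whether the amide-like hydrogen of methylamino matters, which dimethylamino or a plain amine in the same place would test against compound 3. They also leave open whether the ring of compound 4 needs to be aromatic, and how cyclohexyl, or a phenyl bearing a hydroxyl or a methoxy group, would read at this position.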